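This account rests on a few compounds, and the source may have more. Where it says the series, first, only, none or still open, it means among the compounds named here.

Going by the values given here, compound 1 (`Cc1cc(=O)oc2cc(OCC(=O)c3ccccc3C(F)(F)F)ccc12`) gives 20400 nM in a functional assay on CWR22R cells (Homo sapiens) for antiproliferative activity, with a stated time of 96 h (a lower number here means a stronger inhibitor, a higher number a weaker inhibitor), and is the only compound here with a number. Compound 2 (`COc1cccc(C(=O)COc2ccc3c(C(F)(F)F)cc(=O)oc3c2)c1`) is recorded as "not active" (no number reported) without a figure. Compound 3 (`O=C(COc1ccc2c(C(F)(F)F)cc(=O)oc2c1)c1ccccc1C(F)(F)F`) is likewise recorded as "not active" (no number reported) and so has no single number to stand on, and compound 2 is the one further entry of that kind. Compound 4 (`O=C(COc1ccc2c(C(F)(F)F)cc(=O)oc2c1)c1ccccc1`) has not yet been measured. The structural change is hydrogen in place of trifluoromethyl on an aromatic carbon. Among the compounds with values here, the series holds no measured step between compounds that differ in one place, so the size of this step in this assay cannot be read directly. Only a small step is expected, with no clear gain over compound 3. A weak result or another entry without a number is the expected outcome, with compound 1 at 20400 nM as the sole figure to go on. Compound 4 is estimated at 30000 nM with an expected range of 10000 nM to 90000 nM if a number is reported.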

Compound 4, half-maximal inhibitory concentration: "not active" (no number reported)
The entry for compound 4 holds no number; there is nothing to compare the estimate with.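

Compound 3 and compound 4 are both recorded in this assay as not active with no number, so no new step can be read between them. The compounds shown leave open what hydrogen in place of trifluoromethyl does to activity on this core. No measured evidence bears on this result.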